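The source may report more compounds than this note shows. Statements on the series, on what has been measured and on what is new or still open speak of the compounds shown alone.

Measured compounds:
compound 1 `COc1ccc(/C=N/NC(=S)NC(C)(C)[C@H]2CC=C(C)CC2)cc1` gives 43800 nM in a functional assay on NCI/ADR-RES cells (Homo sapiens) for inhibition, read by sulforhodamine B assay, with a stated time of 48 h; a lower number here means a stronger inhibitor of growth, a higher number a weaker inhibitor of growth
compound 2 `CC1=CC[C@H](C(C)(C)NC(=S)N/N=C/c2ccc(O)cc2)CC1` gives 82100 nM in this assay
compound 3 `CC1=CC[C@H](C(C)(C)NC(=S)N/N=C/c2ccccc2O)CC1` gives 3700 nM in this assay

Compound 3 stands lowest of the three numbers: a 12-fold lower number from compound 1 to compound 3 (1.07 log units; beyond the scatter) and a 22-fold lower number from compound 2 to compound 3 (1.35 log units; beyond the scatter), both beyond the scatter. Between the two other compounds the step is small: a 1.9-fold higher number from compound 1 to compound 2 (0.27 log units; within the scatter).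

Compound 4 `CC1=CC[C@H](C(C)(C)NC(=S)N/N=C/c2ccc(F)cc2)CC1` is not yet measured. The change from compound 3 is 4-fluorophenyl in place of 2-hydroxyphenyl on a carbon with a double bond to nitrogen. Among the measured compounds shown here, no measured step exchanges a 2-hydroxyphenyl for a 4-fluorophenyl directly; the steps that bear on it are the two that replace a 4-substituted phenyl with 2-hydroxyphenyl, a 12-fold lower number from compound 1 to compound 3 (1.07 log units; beyond the scatter) and a 22-fold lower number from compound 2 to compound 3 (1.35 log units; beyond the scatter), both large. Compound 4 carries a 4-substituted phenyl again, which on the numbers shown places it with compound 1 and compound 2 rather than with compound 3, so a large higher number is expected in this assay, with the reservation that fluorine has no measured counterpart in the series. Compound 4 is therefore estimated at 40000 nM with a range of 10000 nM to 150000 nM. The expected step is an 11-fold higher number from compound 3 to compound 4 (1.03 log units; beyond the scatter).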

Compound 4, concentration for 50% growth inhibition: > 100000 nM
Compound 4: only a limit was reported (the forecaster's own chance of this, stated with the estimate: 15%); at least 2.5-fold (0.39 log units) between middle value and limit.
By their numbers in this assay, from the lowest: compound 3; then compounds 1 and 2 (each within the scatter of the next). At a limit, above all of these: compound 4.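

Compound 4 gives no number in this assay, only a limit: the limit of > 100000 nM in this assay, at which 1 of the 4 values shown sits.

At this carbon with a double bond to nitrogen, fluoro on a 4-substituted phenyl does not recover the low number of compound 3, as the 2-hydroxyphenyl exchange now read in the opposite direction shows: an at least 27-fold higher number from compound 3 to compound 4 (1.43 log units; beyond the scatter). Fluoro in place of methoxy gives an at least 2.2-fold higher number from compound 1 to compound 4 (0.35 log units; beyond the scatter), whereas fluoro in place of hydroxy gives an at least 1.2-fold higher number from compound 2 to compound 4 (0.08 log units; that floor lies within the scatter), and that floor fixes no order for the pair.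

As far as these compounds go, whether the low number of compound 3 depends on the hydroxy of its 2-hydroxyphenyl stays open, and an amine or a methoxy in place of that hydroxy would bear on this. The compounds shown change only the aromatic group, so the contribution of the shared core also stays open.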